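This account rests on a few compounds, and the source may have more. Where it says the series, first, only, none or still open, it means among the compounds named here.

Measured compounds in an ADME assay on microsomes (Rattus norvegicus) for metabolic stability; on this read-out higher numbers stand for a longer-lived compound and lower numbers for a shorter-lived compound:
compound 1 `O=C(c1cn[nH]c1)N1CCC(C(=O)N2N=CCC2c2ccccc2)CC1`: > 2.75 h
compound 2 `CC(C)C(=O)N1N=CCC1c1ccccc1`: 1.33 h
compound 3 `N#Cc1nccc(N2CCC(C(=O)N3N=CC[C@H]3c3cc(F)cc(F)c3)CC2)n1`: 0.917 h

The result of compound 1 in this assay is a limit of the assay rather than a number, namely > 2.75 h. Compound 1 therefore sits at the limit of > 2.75 h in this assay, at which 1 of the 3 values shown sits, so its true half-life is open upward. Among the compounds with values here, compound 2 gives 1.33 h in this assay, and compound 3 gives 0.917 h; no direct step connects these two compounds to compound 1 or to each other, so their numbers stand on their own.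

Compound 4 `O=C(c1c[nH]nn1)N1CCC(C(=O)N2N=CCC2c2ccccc2)CC1` has not yet been measured. It differs from compound 1 in one place, (1H-1,2,3-triazol-4-yl in place of 1H-pyrazol-4-yl on a carbonyl carbon). Within the data shown here, neither this change nor anything close to it appears among the measured compounds, so there is no measured step to lean on. The expectation is that the step from compound 1 to compound 4 stays small, with an expected change of an at least 1.0-fold lower number from compound 1 to compound 4 (0.02 log units; that floor lies within the scatter), which lies within the usual scatter of repeated measurements. Compound 4 is therefore estimated to give 2.6 h in this assay, with a plausible range from 1.2 h to 5.5 h.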

Compound 4, half-life: > 2.75 h
Compound 4: only a limit was reported; the forecaster's own chance of this, stated with the estimate: 45%; middle value at least 1.0-fold (0.02 log units) from the limit.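

In this assay compound 4 gives > 2.75 h, which is a limit of the assay. Compound 1 gives > 2.75 h, also a limit. Within the data shown here, no step from compound 1 to compound 4 can be read from these two limits: the limit of > 2.75 h in this assay, at which 2 of the 4 values shown sit. The compounds shown leave open the true half-life of each and whether 1H-1,2,3-triazol-4-yl in place of 1H-pyrazol-4-yl changes it at all.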